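A few compounds are considered here, and "the series" means these few. Any claim that something is new, unique, unknown or untested is made for them only; others in the source may bear on it.

Measured in a functional assay on A2780 cells (Homo sapiens) for antiproliferative activity; on this read-out higher numbers stand for weaker inhibition and lower numbers for stronger inhibition:
- compound 1 `Cc1ccc2c(c1C)CN(CCCN(C)C)CC2c1ccccc1`: 3240 nM
- compound 2 `CN(C)C(=O)N1Cc2ccccc2C(c2cccc(O)c2)C1`: "not determined" (no result reported)

Compound 2 has no number to stand on. In this assay the entry for compound 2 reads "not determined" (no result reported), so it cannot be ranked against compound 1, and nothing can be said about its strength. Compound 3 `COc1ccc2c(c1)CN(C(=O)N(C)C)CC2c1cccc(O)c1` is the next to be tested. The structural change is methoxy in place of hydrogen on an aromatic carbon.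

For the measured compounds named here, with no value at the starting end, this change has no measured size, and no step between measured compounds exists to serve as a guide. A single small group is the only difference, so the expectation is a modest step, with neither direction favoured. Going by the values given here, the sole anchor is compound 1 at 3240 nM, and it is a loose one, since compound 1 differs from compound 3 in more than one place. The range therefore has to stay wide. For compound 3 the expected value in this assay is 4000 nM, with an estimated range of 700 nM to 25000 nM.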

Compound 3, half-maximal inhibitory concentration: 402 nM
Estimate against measurement, compound 3: 10-fold (1.00 log units) above; measured number below the stated range.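

In this assay compound 3 gives 402 nM while compound 2 has no number to set against it, and no step can be read between the two. On these data alone, whether methoxy in place of hydrogen on an aromatic carbon strengthens, weakens or leaves unchanged the inhibition stays open. Nothing at hand explains the value of compound 3.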